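The source may hold more compounds than are shown below. What is called first, only, known or untested is meant among the compounds shown, and "the series" means these compounds.

In a functional assay on Caco-2 cells (Homo sapiens) for antiproliferative activity, read by MTT assay, with a stated time of 48 h (on this read-out higher numbers stand for weaker inhibition and lower numbers for stronger inhibition), compound 1 `CCOc1ccc(NC(=O)c2ccc(C(CC)(CC)c3ccc(OCCC(O)(CC)CC)c(C)c3)n2CC)cc1` gives > 50000 nM, which is a limit of the assay and not a number. Among the measured compounds shown here, compound 2 `CCn1c(C(=O)NC(CC(=O)O)C(=O)OC)ccc1C(CC)(CC)c1ccc(OCCC(O)(CC)CC)c(C)c1` gives 25200 nM, the only actual number so far. For the measured compounds named here, the one measured step, an at least 1.9-fold lower number from compound 1 to compound 2 (0.29 log units; that floor lies within the scatter), exchanges the group on an amide-type nitrogen and is the only guide to size. Compound 3 `CCn1c(C(=O)N(C)CCO)ccc1C(CC)(CC)c1ccc(OCCC(O)(CC)CC)c(C)c1` carries a group of 5 heavy atoms (3 carbon, 1 nitrogen, 1 oxygen; no ring) in place of a group of 10 heavy atoms (5 carbon, 1 nitrogen, 4 oxygen; no ring), on a carbonyl carbon, on a carbonyl carbon. The expected step is a 1.2-fold higher number from compound 2 to compound 3 (0.08 log units; within the scatter), with no change expected beyond the scatter in either direction. For compound 3 the estimated value is 30000 nM, with an expected range of 12000 nM to 70000 nM.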

Compound 3, half-maximal inhibitory concentration: 74 nM
Compound 3: the middle estimate sits 410-fold (2.61 log units) above what was measured; the measured number lies below the stated range.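

At the carbonyl carbon, the group carried is now shown to matter in this assay: (2-hydroxyethyl)(methyl)amino gives a 340-fold lower number from compound 2 to compound 3 (2.53 log units; beyond the scatter), whereas the floor of the earlier step lay within the scatter. Against (4-ethoxyphenyl)amino, the change is an at least 670-fold lower number from compound 1 to compound 3 (2.82 log units; beyond the scatter). Compound 1 sits at a limit, so this step is a floor only: the limit of > 50000 nM in this assay, at which 1 of the 3 values shown sits.

Still open, going by these compounds, is whether the hydroxyl of the entering group counts, which a plain dimethylamino group would test. Also open, on these data alone, is whether a longer chain, such as (3-hydroxypropyl)(methyl)amino, keeps the number this low.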